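A Methyl Added to a Weak Inhibitor

The source may hold more compounds than are shown below. What is called first, only, known or untested is meant among the compounds shown, and "the series" means these compounds.

Of the compounds shown here, two have been measured in a functional assay on MCF7 cells (Homo sapiens) for inhibition, with a stated time of 96 h; on this read-out higher numbers stand for weaker inhibition and lower numbers for stronger inhibition. Compound 1, with the structure `CCC1(C)CC(=O)c2cc(O)ccc2O1`, gives 150000 nM in this assay. Compound 2, with the structure `CC1(C)C/C(=N\NC(N)=O)c2cc(O)ccc2O1`, gives 150000 nM in this assay. On the numbers shown, compound 2 stands level with compound 1 at the digits recorded, and no change between them reaches beyond the usual scatter of this kind of measurement. Both, then, are weak inhibitors of these cells, and nothing in their values separates them.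

Compound 3, with the structure `CCC1(C)C/C(=N\NC(N)=O)c2cc(O)ccc2O1`, has not been measured yet. It differs from compound 2 in one place: methyl in place of hydrogen on a saturated chain carbon bound to a saturated ring carbon. Among the measured compounds shown here, no step between measured compounds that matches this change is available, so any expectation rests on how little compound 1 and compound 2 differ from each other.

With that in mind, the step from compound 2 to compound 3 is expected to be no change at the digits printed from compound 2 to compound 3 (within the scatter), which is none beyond the scatter. Compound 3 is therefore estimated to give about 150000 nM in this assay, with a likely range from 75000 nM to 300000 nM.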

Compound 3, half-maximal inhibitory concentration: 70000 nM
Beside the measured number, compound 3's estimate is 2.1-fold (0.33 log units) above it; the whole stated range lies above it.
By their numbers in this assay, from the lowest: compound 3; then compounds 1 and 2 (each within the scatter of the next).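

In this assay, methyl in place of hydrogen on a saturated chain carbon bound to a saturated ring carbon gives a 2.1-fold lower number from compound 2 to compound 3 (0.33 log units; beyond the scatter) and so a modest gain in inhibition. Before this result, no single change at this position could be read, and now it is clear that even one added carbon here, which turns a methyl into an ethyl, can move the read-out past the normal noise of the assay. Still, compound 3 at 70000 nM remains a weak inhibitor of these cells, and nothing measured alongside these compounds explains the step.

Going by these compounds, whether a longer chain such as propyl, or a chain ending in an amine or a carboxylic acid, would extend this small gain or reverse it remains open, since one step cannot show a trend. Also open is whether the same methyl-to-ethyl difference would count for anything with the carbonyl of compound 1 in the core, as a matched partner for that compound is absent from the set shown.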